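A few compounds are considered here, and "the series" means these few. Any claim that something is new, unique, unknown or untested is made for them only; others in the source may bear on it.

In a functional assay on A2780 cells (Homo sapiens) for antiproliferative activity, read by MTT assay, with a stated time of 72 h (on this read-out lower numbers stand for stronger inhibition and higher numbers for weaker inhibition), compound 1 `CC(C)NC(=N)NC(=N)Nc1ccc(C(F)(F)F)cc1` gives 3200 nM, compound 2 `CC(C)CNC(=N)NC(=N)Nc1ccc(C(F)(F)F)cc1` gives 2100 nM and compound 3 `CC(C)NC(=N)NC(=N)Nc1ccc(F)cc1` gives 28000 nM. Compound 2 therefore sits at the low end of these numbers, level with compound 1 given the usual scatter, while compound 3 stands clearly higher. Compound 4 `CCN(C)C(=N)NC(=N)Nc1ccc(C(F)(F)F)cc1` differs from compound 2 by a single change on a carbon with a double bond to nitrogen: ethyl(methyl)amino in place of isobutylamino on a carbon with a double bond to nitrogen.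

The closest measured step also concerns a group on an amine nitrogen, isobutyl in place of isopropyl, and it is small: a 1.5-fold lower number from compound 1 to compound 2 (0.18 log units; within the scatter). The other step, an 8.8-fold higher number from compound 1 to compound 3 (0.94 log units; beyond the scatter), is larger, but it swaps fluoro for trifluoromethyl on an aromatic carbon, so it says little about this change. Among the compounds with values here, no measured compound carries an ethyl(methyl)amino group, which leaves real uncertainty. In this assay the expected step is a 1.9-fold higher number from compound 2 to compound 4 (0.28 log units; within the scatter), a slight move towards a higher number that is not expected to clearly exceed the scatter. For compound 4 the estimated value is 4000 nM, with an expected range of 1500 nM to 11000 nM.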

Compound 4, half-maximal inhibitory concentration: 5100 nM
Compound 4: the middle estimate sits 1.3-fold (0.11 log units) below what was measured, and the stated range covers the measured number.
By their numbers in this assay, from the lowest: compounds 2, 1 and 4 (each within the scatter of the next, the first and the last beyond it); then compound 3.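

In this assay, within the data shown here, this is the first look at a group on this carbon that carries no hydrogen-bond donor, since ethyl(methyl)amino counts none where isobutylamino counts one. Exchanging isobutylamino for ethyl(methyl)amino gives a 2.4-fold higher number from compound 2 to compound 4 (0.39 log units; beyond the scatter), a modest step that goes beyond the scatter, while exchanging isopropylamino for the same group gives a 1.6-fold higher number from compound 1 to compound 4 (0.20 log units; within the scatter), which stays within it, so the size of the effect depends on which group is taken as the starting point. No measurement here accounts for either step.

Still open, going by these compounds, is how a longer chain such as hexylamino, or a ring such as piperidinyl, would read on this carbon. On these data alone, it is also open whether ethyl(methyl)amino would give a similar step with fluoro in place of trifluoromethyl on the aromatic carbon.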